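From compound 2 to compound 4: a series at its limit

The source may report more compounds than this note shows. Statements on the series, on what has been measured and on what is new or still open speak of the compounds shown alone.

Compound 1 `COc1cc(-c2cccc3nc(-c4ccccc4)oc23)cc(OC)c1OC` gives > 25000 nM
Compound 2 `COc1ccc(-c2nc3cccc(-c4cc(OC)c(OC)c(OC)c4)c3o2)cc1OC` gives > 25000 nM
Compound 3 `COc1cc(-c2cccc3nc(-c4cccc(F)c4)oc23)cc(OC)c1OC` gives > 25000 nM

These three entries come from a functional assay on MCF7 cells (Homo sapiens) for antiproliferative activity, read by MTT assay, with a stated time of 48 h (a lower number here means a stronger inhibitor, a higher number a weaker inhibitor), and each is a limit and not a number. The whole set comes down to one reading: the limit of > 25000 nM in this assay, at which 3 of the 3 values shown sit. Compound 2 therefore stands only as a limit, with no number to start from.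

Compound 4 `COc1cc(-c2cccc3nc(-c4cccc(Cl)c4)oc23)cc(OC)c1OC` has yet to be measured. Its difference from compound 2 is 3-chlorophenyl in place of 3,4-dimethoxyphenyl on an aromatic carbon. In words, 3-chlorophenyl stands in place of 3,4-dimethoxyphenyl on an aromatic carbon.

The closest measured change puts 3-fluorophenyl at the same place, and it is a step that the two limits leave unreadable from compound 2 to compound 3. The other two are a step that the two limits leave unreadable from compound 1 to compound 2 and a step that the two limits leave unreadable from compound 1 to compound 3. None of them gives a size, so no step beyond the scatter is expected in this assay, in either direction.

The expectation leans on compound 3 , whose limit is > 25000 nM. The estimated change is a step that the limit leaves unreadable from compound 2 to compound 4. Compound 4 is expected at 30000 nM, with an estimated range from 15000 nM to 60000 nM, and most likely as a limit again.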

Compound 4, half-maximal inhibitory concentration: > 25000 nM
Compound 4: only a limit was reported; the forecaster's own chance of this, stated with the estimate: 85%; the middle value does not contradict the limit.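

Compound 4 is again only a limit, so its steps from compound 1, compound 2 and compound 3 cannot be read, and the set stays at a single reading: the limit of > 25000 nM in this assay, at which 4 of the 4 values shown sit.

The compounds shown leave open how these four rank against one another in this assay, and whether any change to the shared core would give a measurable value.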